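This account rests on a few compounds, and the source may have more. Where it says the series, first, only, none or still open, it means among the compounds named here.

Values in an ADME assay on cells (Fibroblast, Homo sapiens) for antiproliferative activity, with a stated time of 48 h (on this read-out lower numbers stand for stronger inhibition and higher numbers for weaker inhibition), are as follows:
- Compound 1 `CCN(CC)c1ccc(-c2ccc(C(C)=O)cc2)nn1` gives > 25000 nM as a limit of the assay
- Compound 2 `CCN(CC)c1ccc(-c2ccc(C(=O)O)cc2)nn1` gives > 25000 nM as a limit of the assay
- Compound 3 `CCOC(=O)c1ccc(-c2ccc(N(CC)CC)nn2)cc1` gives 3000 nM as a measured number

Among the compounds with values here, compound 3 is the only member of the set with a number. The other two compounds stand at the limit of > 25000 nM in this assay, at which 2 of the 3 values shown sit, and cannot be ranked against each other.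

Compound 4 `CCOC(=O)c1ccc(-c2ccc(N(C)C)nn2)cc1` is the next point, with dimethylamino in place of diethylamino on an aromatic carbon and the rest of compound 3 unchanged.

Within the data shown here, no measured step touches this position, since all three measured compounds carry diethylamino. The two readable steps, an at least 8.3-fold lower number from compound 1 to compound 3 (0.92 log units; beyond the scatter) and an at least 8.3-fold lower number from compound 2 to compound 3 (0.92 log units; beyond the scatter), both lie at the carbonyl end of the molecule. They show that the read-out can move beyond the scatter, but they give no size for a change at the amino group. The working expectation therefore starts from compound 3 at 3000 nM with no clear direction.

The expected step is a 1.3-fold higher number from compound 3 to compound 4 (0.12 log units; within the scatter) and no shift beyond the scatter is expected. From the compounds shown here alone, the range is kept wide, as this position is untested.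

In this assay the estimate for compound 4 is 4000 nM, with an expected range from 1200 nM to 14000 nM.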

Compound 4, half-maximal inhibitory concentration: > 25000 nM
Compound 4 was reported as a limit (the forecaster's own chance of this, stated with the estimate: 15%); at least 6.2-fold (0.79 log units) between middle value and limit.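

Within the data shown here, at the amino group on the aromatic carbon, dimethylamino in place of diethylamino gives an at least 8.3-fold higher number from compound 3 to compound 4 (0.92 log units; beyond the scatter) in this assay, so this position, which no earlier step touched, also moves the read-out beyond the scatter, as the steps at the carbonyl end did. Compound 4 gives > 25000 nM, which is a limit of the assay, so the full size of this step stays unread. A measured number in the set now rests on compound 3 alone, the one compound that combines diethylamino with ethoxy on the carbonyl carbon, and the other compounds share one limit: the limit of > 25000 nM in this assay, at which 3 of the 4 values shown sit.

The compounds shown leave open whether a longer chain on the amino nitrogen, as in dipropylamino, or a cyclic amine such as pyrrolidine or piperidine in the same place would hold or go past compound 3 at 3000 nM. Also open, from the compounds shown here alone, is whether dimethylamino paired with a larger group on the carbonyl carbon, such as isopropoxy, would return a measured number rather than a limit.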